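Cyanoguanidine series: cyclopentyl for thiophen-3-yl at the saturated carbon

The compounds below may be only part of what the source reports. "The series", "measured", "known", "first", "only" and "open" are said of these compounds alone.

Three compounds of the series have been run in an assay on cells for displacement of a labelled ligand from adenosine receptor A1 (Homo sapiens), with a stated time of 60 min, tested at 1 uM; a higher number here means more inhibition at the concentration tested (going by the name of the read-out), a lower number less inhibition. Compound 1 `CC1=C(C(=O)OC(C)C)[C@H](c2ccco2)N/C(=N/C#N)N1` gives 18%. Compound 2 `CCOC(=O)C1=C(C)N/C(=N\C#N)NC1c1ccsc1` gives 29%. Compound 3 `CC1=C(C(=O)OC(C)C)C(C2CCCC2)NC(=O)N1` gives 1%. Compound 2 thus stands highest of the three, with compound 1 the nearest number and compound 3 the furthest, both beyond the scatter of this assay.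

Compound 4 `CCOC(=O)C1=C(C)N/C(=N\C#N)NC1C1CCCC1` has not yet been measured. It keeps the core and the ethoxycarbonyl group of compound 2, and the change is cyclopentyl in place of thiophen-3-yl on a saturated ring carbon.

Among the measured compounds shown here, no step between two measured compounds differing in a single place is available for this exchange. Compound 3, which also carries cyclopentyl and gives 1%, differs from compound 4 in more than one place, so it points only loosely. A downward step is nevertheless expected for compound 4.

The step estimated for compound 4 in this assay is a number 17 percentage points lower from compound 2 to compound 4 (beyond the scatter). Compound 4 is expected to give about 12%, with a range from 2% to 30%.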

Compound 4, a percentage reported as inhibition, at one concentration (the size of the read-out at that concentration, not a potency): 11%
Compound 4: middle estimate off by 1 percentage points, on the high side; the measured number falls inside the stated range.
By their numbers in this assay, from the lowest: compounds 3, 4 and 1 (each within the scatter of the next, the first and the last beyond it); then compound 2.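

Among the compounds shown here, with the core and the ethoxycarbonyl group held fixed, the exchange of thiophen-3-yl for cyclopentyl on the saturated ring carbon gives the first single-place step in this assay: a number 18 percentage points lower from compound 2 to compound 4 (beyond the scatter). This position is therefore not indifferent to its group, since a five-membered aromatic ring with one hetero atom and a five-membered all-carbon non-aromatic ring, equal in heavy atoms, do not read the same. No measurement at hand accounts for this step.

Open, as far as these compounds go, is whether the aromatic character, the sulfur or its hydrogen-bond acceptor count carries the step, a question that phenyl or pyridin-3-yl at this carbon would begin to address. Also open, from the compounds shown here alone, is how an open chain such as n-butyl, or a ring bearing an amine, would read at this position.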